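The source may hold more compounds than are shown below. What is called first, only, known or untested is meant among the compounds shown, and "the series" means these compounds.

Measured so far:
compound 1 `COc1ccc(-c2occc2-c2cc(OC)c(OC)c(OC)c2)cc1O` — 20 nM
compound 2 `COc1ccc(-c2ccoc2-c2cc(OC)c(OC)c(OC)c2)cc1O` — 3.1 nM
compound 3 `COc1cc(-c2cscc2-c2ccc(C)c(F)c2)cc(OC)c1OC` — 420 nM

In a functional assay on HeLa cells (Homo sapiens) for cytotoxicity, read by MTT assay, with a stated time of 48 h (on this read-out lower numbers stand for stronger inhibition and higher numbers for weaker inhibition), compound 3 gives 420 nM, the highest of the three numbers. Compound 1 gives 20 nM and compound 2 gives 3.1 nM; the gaps from compound 3 to each of them lie beyond the scatter, so compound 3 sits clearly at the weak end of what has been measured.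

Compound 4 `COc1ccc(-c2cscc2-c2cc(OC)c(OC)c(OC)c2)cc1` is not yet measured. It differs from compound 3 in one place: 4-methoxyphenyl in place of 3-fluoro-4-methylphenyl on an aromatic carbon. Going by the values given here, no pair of measured compounds isolates this change, so there is no measured step to lean on. What the numbers show is that the two compounds whose structures stand closer to compound 4 than compound 3 does, compounds 1 and 2, give the two low values, while compound 3 stands alone at the high end.

The step from compound 3 to compound 4 is expected to be a 7.0-fold lower number from compound 3 to compound 4 (0.85 log units; beyond the scatter), a move toward lower numbers and beyond the scatter. Compound 4 is expected to give 60 nM, within a range of 10 nM to 350 nM.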

Compound 4, half-maximal inhibitory concentration: 420 nM
Estimate against measurement, compound 4: 7.0-fold (0.85 log units) below; the whole stated range lies below it.
By their numbers in this assay, from the lowest: compound 2; then compound 1; then compounds 3 and 4 (each within the scatter of the next).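

In this assay, going by these compounds alone, the exchange of 3-fluoro-4-methylphenyl for 4-methoxyphenyl on this aromatic carbon gives no change at the digits printed from compound 3 to compound 4 (within the scatter) and is the only measured step at this position. On this read-out the two groups cannot be told apart here, even though they differ in atoms and the entering group carries a hydrogen-bond acceptor that the leaving group lacks. Nothing at hand accounts for this result.

The compounds shown leave open whether an amine, a carboxylic acid or a longer chain such as butoxy at this position would shift the number beyond the scatter. On these data alone, it also remains open whether the two groups would match on a core other than that of compound 4.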